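Cytotoxicity in Raji cells: acid, ester and biaryl swaps

The compounds below may be only part of what the source reports. "The series", "measured", "known", "first", "only" and "open" are said of these compounds alone.

The shared core is taken as compound 1, `CC(C)N(Cc1cccc(OCCCCCC(=O)O)c1)C(=O)c1ccc(-c2ccc3cc[nH]c3c2)cc1`. In an ADME assay on Raji cells (Homo sapiens) for cytotoxicity, read by CellTiter-Glo and resazurin assay, with a stated time of 72 h (a higher number here means that more compound is needed for the effect, a lower number that less compound is needed), compound 1 reaches only a limit, > 26000 nM. Compound 2, `COc1cc(OC)cc(-c2ccc(C(=O)N(Cc3cccc(OCCCCCC(=O)O)c3)C(C)C)cc2)c1`, differs from it by 3,5-dimethoxyphenyl in place of 1H-indol-6-yl on an aromatic carbon. In this assay compound 2 likewise reaches only a limit, > 26000 nM. Compound 3, `CCOC(=O)CCCCCOc1cccc(CN(C(=O)c2ccc(-c3ccc4cc[nH]c4c3)cc2)C(C)C)c1`, differs from compound 1 by ethyl in place of hydrogen on an oxygen next to a carbonyl group. In this assay compound 3 again reaches only a limit, > 26000 nM. The step that the two limits leave unreadable from compound 1 to compound 2 and the step that the two limits leave unreadable from compound 1 to compound 3 therefore cannot be sized, because of the limit of > 26000 nM in this assay, at which 3 of the 3 values shown sit. Going by the values given here, nothing among the measured compounds separates the acid from the ethyl ester, or the indolyl biaryl from the dimethoxyphenyl biaryl, within the tested range.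

Compound 4, `CCOC(=O)CCCCCOc1cccc(CN(C(=O)c2ccc(-c3cc(OC)cc(OC)c3)cc2)C(C)C)c1`, remains to be measured. It differs from compound 3 by 3,5-dimethoxyphenyl in place of 1H-indol-6-yl on an aromatic carbon, the same change, at the same place, as from compound 1 to compound 2. The expected step is a step that the limit leaves unreadable from compound 3 to compound 4, an estimate resting on the fact that every measured value sits at the limit of > 26000 nM in this assay, at which 3 of the 3 values shown sit. Compound 4 is thus expected to give about 30000 nM, estimated between 15000 nM and 80000 nM, most likely reported as a limit only.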

Compound 4, half-maximal effective concentration: > 26000 nM
Compound 4 gave a limit, no number; the forecaster's own chance of this, stated with the estimate: 85%; the middle value is on the limit's open side.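

In this assay compound 4 gives > 26000 nM, a limit and not a number. The steps from compound 3 to compound 4 and from compound 2 to compound 4 cannot be read, because all the values rest on one limit: the limit of > 26000 nM in this assay, at which 4 of the 4 values shown sit.

The compounds shown leave open whether the acid and the ethyl ester, or the 1H-indol-6-yl and 3,5-dimethoxyphenyl groups, differ at all in this assay.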